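A few compounds are considered here, and "the series" means these few. Any claim that something is new, unique, unknown or untested is made for them only; others in the source may bear on it.

Compound 1 `O=C(Nc1ccc(OC(F)(F)F)cc1)NC1CCN(C(=O)c2ccoc2)CC1` stands highest of the three compounds measured in a physicochemical assay for solubility, read by mass spectrometry, in phosphate buffer, with a stated time of 24 h, at pH 7.4 (on this read-out higher numbers stand for higher solubility and lower numbers for lower solubility), where compound 1 gives 7.6 ug/mL. Compound 3 `O=C(Nc1ccc(C(F)(F)F)cc1)NC1CCN(C(=O)c2ccoc2)CC1` gives 2.2 ug/mL, and compound 2 `Cc1ccoc1C(=O)N1CCC(NC(=O)Nc2ccc(C(F)(F)F)cc2)CC1` gives 0.8 ug/mL. The two measured steps are modest: a 3.5-fold lower number from compound 1 to compound 3 (0.54 log units; beyond the scatter), and a 2.8-fold higher number from compound 2 to compound 3 (0.44 log units; beyond the scatter). Both changes sit away from the ring that is altered next, one on the aromatic carbon of the phenyl urea and the other on the furan carbon that carries the methyl.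

Compound 4 `O=C(Nc1ccc(OC(F)(F)F)cc1)NC1CCN(C(=O)c2cc[nH]c2)CC1` differs from compound 1 by 1H-pyrrol-3-yl in place of furan-3-yl on a carbonyl carbon. Going by the values given here, no measured step swaps the furan oxygen for a nitrogen, so neither step bears directly on this change, and the two steps that are known give no direction for it. With no guide, the expected step is a 1.3-fold lower number from compound 1 to compound 4 (0.10 log units; within the scatter), which lies within the scatter. Compound 4 is therefore estimated at 6 ug/mL in this assay, with a range from 2 ug/mL to 18 ug/mL.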

Compound 4, solubility: 43 ug/mL
Estimate against measurement, compound 4: 7.2-fold (0.86 log units) below; the measured number lies above the stated range.
By their numbers in this assay, from the lowest: compound 2; then compound 3; then compound 1; then compound 4.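

At the carbonyl carbon, 1H-pyrrol-3-yl in place of furan-3-yl gives a 5.7-fold higher number from compound 1 to compound 4 (0.75 log units; beyond the scatter) in this assay, so exchanging only the ring's oxygen for a nitrogen carrying a hydrogen moves the number beyond the usual scatter. Going by these compounds alone, the one earlier step at this place, a 2.8-fold higher number from compound 2 to compound 3 (0.44 log units; beyond the scatter), stayed within the furans, so it did not test a change of hetero atom. The entering ring counts one hydrogen-bond donor and the leaving ring none, but no measurement here shows whether that difference explains the step.

The compounds shown leave open whether the same ring exchange gives a similar step with trifluoromethyl on the aromatic carbon, as in compound 3. They also leave open how a thiophene, an imidazole or a pyrrole with a methyl on its nitrogen would read at this carbonyl carbon.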